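The source may hold more compounds than are shown below. What is called first, only, known or untested is meant among the compounds shown, and "the series" means these compounds.

Of the compounds shown here, three have a number so far. Compound 1, `O=C1CCCC/C1=C\c1ccccc1[N+](=O)[O-]`, gives 23800 nM in a functional assay on L1210 cells (Mus musculus) for cytotoxicity, with a stated time of 48 h; a lower number here means a stronger inhibitor, a higher number a weaker inhibitor. Compound 2, `O=C1CCCC/C1=C\c1ccc([N+](=O)[O-])cc1`, gives 46500 nM in this assay. Compound 3, `O=C1/C(=C/c2ccc(F)cc2)CCC/C1=C\c1ccccc1[N+](=O)[O-]`, gives 8400 nM in this assay, the lowest of the three numbers; its gap to compound 1, the nearest of the other two, lies beyond the usual scatter, and its gap to compound 2 is wider still. Compound 4, `O=C1/C(=C/c2ccccc2)CCC/C1=C\c1ccccc1[N+](=O)[O-]`, has not yet been measured in this assay. It differs from compound 3 in one place only: hydrogen in place of fluoro on an aromatic carbon. Going by the values given here, no pair of measured compounds shows this change, so nothing in the numbers above tells how large the step should be. The account expects the change from compound 3 to compound 4 to bring at most a modest loss in this assay, of a size that may not clear the scatter, as a 1.3-fold higher number from compound 3 to compound 4 (0.12 log units; within the scatter). Compound 4 is therefore expected to give about 11000 nM in this assay, within a range from 5000 nM to 25000 nM.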

Compound 4, half-maximal inhibitory concentration: 4840 nM
For compound 4 the middle estimate is 2.3-fold (0.36 log units) above the measured one; the measured number lies below the stated range.
By their numbers in this assay, from the lowest: compounds 4 and 3 (each within the scatter of the next); then compounds 1 and 2 (each within the scatter of the next).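

Going by these compounds alone, the step of a 1.7-fold lower number from compound 3 to compound 4 (0.24 log units; within the scatter) in this assay gives the first reading of 4-fluorophenyl to phenyl, and it stays within the scatter. At this place, on an aromatic carbon para to a large group, hydrogen in place of fluoro therefore leaves no difference that these numbers can resolve, and the fluoro group is not needed to keep the number at this level. No measurement given here bears on what lies behind this step.

On these data alone, only fluoro and hydrogen have values at this place, so it remains open whether a chloro, a methoxy or an amine there would move the number beyond the scatter. As far as these compounds go, whether fluoro to hydrogen would read the same if a carboxylic acid replaced the nitro group on the other aromatic ring also remains open.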